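The compounds below may be only part of what the source reports. "The series", "measured", "known", "first", "only" and "open" are said of these compounds alone.

Compound 1 `Nc1nc(N)c(CCCN(Cc2ccc(NC(CCC(=O)O)C(=O)O)cc2)c2cc(F)c(F)cc2[N+](=O)[O-])c(O)n1` was tested in a functional assay on CCRF-CEM cells (Homo sapiens) for cytotoxicity, in the presence of a further agent that is not named here; on this read-out lower numbers stand for stronger inhibition and higher numbers for weaker inhibition. In this assay compound 1 gives > 100000 nM, which is a limit of the assay and not a number. Compound 3 `Nc1nc(N)c(CCCN(Cc2ccc(NC(CCC(=O)O)C(=O)O)cc2)c2cc(F)ccc2[N+](=O)[O-])c(O)n1` differs from compound 1 by hydrogen in place of fluoro on an aromatic carbon. In this assay compound 3 also gives > 100000 nM, again a limit rather than a number. The step that the two limits leave unreadable from compound 1 to compound 3 is therefore unreadable, as the limit of > 100000 nM in this assay, at which 2 of the 3 values shown sit, shows where both values sit. Going by the values given here, compound 2 `CC(C)(C)OC(=O)CCC(Nc1ccc(CN(CCCc2c(N)nc(N)nc2O)c2cc(F)cc(F)c2[N+](=O)[O-])cc1)C(=O)OC(C)(C)C` is the only compound with a number: in this assay compound 2 gives 7700 nM. How the core of compound 2 differs from the core of compound 1 is not broken down here. Compound 4 `CC(C)(C)OC(=O)CCC(Nc1ccc(CN(CCCc2c(N)nc(N)nc2O)c2cc(F)ccc2[N+](=O)[O-])cc1)C(=O)OC(C)(C)C` is not yet measured; it differs from compound 2 by hydrogen in place of fluoro on an aromatic carbon. This is the same kind of change as that from compound 1 to compound 3, but the place differs: here the carbon is ortho to a nitro group, meta to a fluoro group and meta to a large group, whereas in compound 1 it is ortho to a fluoro group, meta to a nitro group and para to a large group. Since the measured step has no readable size, the expected step of a 1.0-fold higher number from compound 2 to compound 4 (0.02 log units; within the scatter) is set near zero. Compound 4 is accordingly estimated at 8000 nM, between 3000 nM and 25000 nM.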

Compound 4, half-maximal inhibitory concentration: 14000 nM
Compound 4: middle estimate off by 1.8-fold (0.24 log units), on the low side; the range from low to high includes it.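

In this assay, the replacement of fluoro by hydrogen that turns 3,5-difluoro-2-nitrophenyl into 5-fluoro-2-nitrophenyl comes with a 1.8-fold higher number from compound 2 to compound 4 (0.26 log units; within the scatter), so on this core the change cannot be told apart from repeat-measurement scatter. The same kind of change on the core of compound 1, leading to compound 3, cannot be read, because both values of that pair are limits of the assay and not numbers: the limit of > 100000 nM in this assay, at which 2 of the 4 values shown sit.

The result therefore describes one core and one place on the ring; it does not show that the change carries over from one core to the other, and the carbon that changes also has different neighbours in the two pairs.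

The compounds shown leave open whether chloro, methoxy or an amine at the carbon that changes between compound 2 and compound 4 would also stay within the scatter. They also leave open how an amine in place of the nitro group would read on either core.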